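The source may hold more compounds than are shown below. What is called first, only, known or untested is meant among the compounds shown, and "the series" means these compounds.

Compound 2, `O=C(Nc1ccccc1)c1cc(Oc2ccc(/C=C/c3ccncc3)cc2)ccn1`, is the weaker of the two measured compounds: in a functional assay on A549 cells (Homo sapiens) for antiproliferative activity, read by CCK-8 assay, with a stated time of 48 h (a lower number here means a stronger inhibitor, a higher number a weaker inhibitor), compound 2 gives 79700 nM, the highest of the two numbers recorded so far. Its nearest neighbour, compound 1 with structure `CC(C)NC(=O)c1cc(Oc2ccc(/C=C/c3ccccn3)cc2)ccn1`, gives 21400 nM in this assay, a gap that lies beyond the scatter; the two compounds differ in more than one place, so nothing more can be read from that pair.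

Compound 3, `O=C(c1cc(Oc2ccc(/C=C/c3ccncc3)cc2)ccn1)N1CCCC1`, is not yet measured. Relative to compound 2 it carries pyrrolidin-1-yl in place of anilino on a carbonyl carbon. For the measured compounds named here, no single-change step between measured compounds is available to guide this change, so the expectation rests on the two values alone. The step from compound 2 to compound 3 is expected to be small, a 1.8-fold lower number from compound 2 to compound 3 (0.25 log units; within the scatter), leaning toward a lower number but hardly beyond the scatter. Compound 3 is therefore estimated at 45000 nM, within 12000 nM to 150000 nM.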

Compound 3, half-maximal inhibitory concentration: 18600 nM
Compound 3: middle estimate off by 2.4-fold (0.38 log units), on the high side, within the range that was stated.
By their numbers in this assay, from the lowest: compounds 3 and 1 (each within the scatter of the next); then compound 2.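

For the compounds shown here, the step from anilino to pyrrolidin-1-yl on the carbonyl carbon gives a 4.3-fold lower number from compound 2 to compound 3 (0.63 log units; beyond the scatter) in this assay and is the only single-change comparison here, showing that the number responds to what sits on this carbonyl carbon. The change removes a hydrogen-bond donor and a six-membered aromatic ring of carbon only, and brings in a five-membered non-aromatic ring, but these differences arrive together and this one step cannot tell them apart. Nothing measured here bears on why the number falls.

On these data alone, it remains open whether the ring or the amide hydrogen matters more. A cyclohexylamino group would keep the amide hydrogen without the aromatic ring, while a piperidin-1-yl or dimethylamino group on the same carbonyl carbon would test other groups lacking it.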